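From a hydroxy chain to a carboxy group

A few compounds are considered here, and "the series" means these few. Any claim that something is new, unique, unknown or untested is made for them only; others in the source may bear on it.

Measured in an ADME assay on S9 fraction from liver (Rattus norvegicus) for metabolic stability, read by LC-MS, using NADPH, with a stated time of 60 min, tested at 10 uM; on this read-out lower numbers stand for a less stable compound and higher numbers for a more stable compound:
compound 1 `N#CC1(c2cc(CCO)cc(-c3ccnc4[nH]nc(C(F)(F)F)c34)c2)CC1`: 17%
compound 2 `CCC(O)Cc1cc(-c2ccnc3[nH]nc(C(F)(F)F)c23)cc(C2(C#N)CC2)c1`: 17%

Compound 1 sets the level, and compound 2 stands with it at 17%. The next structure, compound 3 `N#CC1(c2cc(CC(=O)O)cc(-c3ccnc4[nH]nc(C(F)(F)F)c34)c2)CC1`, alters the same chain: carboxy in place of 1-hydroxypropyl on a saturated chain carbon bound to an aromatic carbon. In words, this is carboxy in place of 1-hydroxypropyl on a saturated chain carbon bound to an aromatic carbon. Within the data shown here, only one measured step bears on this change, ethyl in place of hydrogen on the chain, and it shows no change at the digits printed from compound 1 to compound 2 (within the scatter). Among the measured compounds shown here, that step kept the hydroxy group, while compound 3 has none, and no measurement yet covers its loss. With compound 2 at 17%, a rise is expected, though its size is poorly fixed. The expected move in this assay is a number 43 percentage points higher from compound 2 to compound 3 (beyond the scatter). For compound 3 the estimated value is 60%, with an expected range from 25% to 95%.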

Compound 3, percent of the compound remaining: 95%
For compound 3 the middle estimate is 35 percentage points below the measured one, within the range that was stated.
By their numbers in this assay, from the lowest: compounds 1 and 2 (each within the scatter of the next); then compound 3.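

At this place, on a saturated chain carbon bound to an aromatic carbon, the earlier compounds had shown only two hydroxy chains level with each other in this assay. Carboxy now moves the read-out, giving a number 78 percentage points higher from compound 2 to compound 3 (beyond the scatter) in place of 1-hydroxypropyl and a number 78 percentage points higher from compound 1 to compound 3 (beyond the scatter) in place of hydroxymethyl. The position is therefore not indifferent to what it carries: adding ethyl to the chain left the number unchanged, whereas carboxy gives a large step from either hydroxy compound.

Going by these compounds, whether the gain belongs to the carboxylic acid itself or simply follows the loss of the hydroxy group stays open, and a primary amide, a methyl ester or a longer chain ending in carboxy at this place would separate the two. The information at hand offers no explanation for the size of this step.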